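Methoxy addition on the pyrazoline aryl: second pass

A few compounds are considered here, and "the series" means these few. Any claim that something is new, unique, unknown or untested is made for them only; others in the source may bear on it.

Three compounds of the series have numbers in a functional assay on A549 cells (Homo sapiens) for antiproliferative activity, with a stated time of 72 h; a higher number here means a weaker inhibitor, a lower number a stronger inhibitor. Compound 1 `COc1ccc(C2CC(c3ccccc3)=NN2c2nc(-c3ccccc3)c(C#N)c(=O)n2C)cc1` gives 1760 nM in this assay. Compound 2 `COc1ccc(C2=NN(c3nc(-c4ccccc4)c(C#N)c(=O)n3C)C(c3ccc(OC)cc3)C2)cc1` carries a methoxy in place of a hydrogen relative to compound 1, the change being (methoxy in place of hydrogen on an aromatic carbon), and compound 2 gives 26500 nM in this assay. That single change made a step of a 15-fold higher number from compound 1 to compound 2 (1.18 log units; beyond the scatter). Compound 3 `Cn1c(N2N=C(c3ccc(Cl)cc3)CC2c2ccccc2)nc(-c2ccc(Cl)cc2)c(C#N)c1=O` gives 43900 nM in this assay; it stands highest of the three numbers, but its gap to compound 2 lies within the scatter, while its gap to compound 1 lies beyond it. The difference between the core of compound 3 and the core of compound 1 is not broken down here.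

Compound 4 `COc1ccc(C2CC(c3ccc(Cl)cc3)=NN2c2nc(-c3ccc(Cl)cc3)c(C#N)c(=O)n2C)cc1` is not yet measured. It differs from compound 3 by methoxy in place of hydrogen on an aromatic carbon, the same change that turned compound 1 into compound 2, so the change occurs twice among the compounds shown, and the place of the change reads identically in both cases.

The expectation for compound 4 rests on the one measured occurrence of this change, where adding the methoxy raised the number by a 15-fold higher number from compound 1 to compound 2 (1.18 log units; beyond the scatter), and on the already high starting number of compound 3 at 43900 nM. The step from compound 3 to compound 4 in this assay is expected at a 2.7-fold higher number from compound 3 to compound 4 (0.44 log units; beyond the scatter). Compound 4 is therefore estimated at 120000 nM in this assay, with a range from 35000 nM to 400000 nM, and there is a fair chance that the assay returns only a limit.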

Compound 4, half-maximal inhibitory concentration: 35700 nM
The estimate for compound 4 lay 3.4-fold (0.53 log units) above the measured number, within the range that was stated.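

Methoxy in place of hydrogen on an aromatic carbon, read as phenyl to 4-methoxyphenyl, now gives a 1.2-fold lower number from compound 3 to compound 4 (0.09 log units; within the scatter) in this assay, and the large step seen on the core of compound 1 does not reappear on the second core, so the two occurrences of this one change differ: the same change on two cores in this assay, a 15-fold higher number (1.18 log units; beyond the scatter) from compound 1 to compound 2 and a 1.2-fold lower number (0.09 log units; within the scatter) from compound 3 to compound 4, 19-fold (1.27 log units) apart, beyond the scatter of two such steps

In this series, then, the size of the step measured on one core cannot be carried over to the other core, even though the place of the change reads identically in both pairs. What this does not show is which of the differences between the two cores sets the outcome, or how the change would read on any further core, since two pairs give a contrast and not a rule, and no property of the methoxy is measured here.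

Open, from the compounds shown here alone, is whether a single chlorine on only one of the two outer aromatic rings is enough to separate the two outcomes. Also open, going by these compounds, is how an amine or a carboxylic acid in place of the methoxy, at the same place, would read on each of the two cores.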